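Replacing a Methyltetrazole with a Methylpyrazole in a Urea Series

The source may report more compounds than this note shows. Statements on the series, on what has been measured and on what is new or still open speak of the compounds shown alone.

Measured in a functional assay on a cell-free system (plasma) with sterol O-acyltransferase, Soat (Rattus norvegicus) as the target; on this read-out lower numbers stand for an effect already at smaller amounts and higher numbers for an effect only at larger amounts of compound:
- Compound 1 `Cc1cc(C)c(NC(=O)N(Cc2cccc(-c3nnn(C)n3)c2)C2CCCCCC2)c(C)c1` is reported only as a limit, < 1 mg/kg.
- Compound 2 `Cc1cc(C)c(NC(=O)N(Cc2ccccc2)Cc2cccc(-c3cc[nH]n3)c2)c(C)c1` is likewise reported only as a limit, > 1 mg/kg.

Neither value is a number, so compound 1 cannot be placed against compound 2 beyond what the two limits show: one sits at the limit of < 1 mg/kg in this assay, at which 1 of the 2 values shown sits, and the other at the limit of > 1 mg/kg in this assay, at which 1 of the 2 values shown sits. Going by the values given here, no step between measured compounds that differ in one place is available, and the two compounds differ in more than one place, so nothing is said here about the effect of any single change among them.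

Compound 3 `Cc1cc(C)c(NC(=O)N(Cc2cccc(-c3ccnn3C)c2)C2CCCCCC2)c(C)c1` is not yet measured. It differs from compound 1 by 1-methyl-1H-pyrazol-5-yl in place of 2-methyl-2H-tetrazol-5-yl on an aromatic carbon. Among the compounds with values here, with no measured step to rest on, the step from compound 1 to compound 3 in this assay is expected to stay within the usual scatter, in no particular direction, as a step that the limit leaves unreadable from compound 1 to compound 3. Compound 3 is therefore estimated at 0.7 mg/kg, with a range from 0.15 mg/kg to 3 mg/kg.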

Compound 3, dose for half-maximal effect: > 1 mg/kg
Compound 3: only a limit was reported; the forecaster's own chance of this, stated with the estimate: 55%; middle value at least 1.4-fold (0.15 log units) from the limit.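

In this assay, placing 1-methyl-1H-pyrazol-5-yl in place of 2-methyl-2H-tetrazol-5-yl on an aromatic carbon, meta to a large group, gives a number no lower from compound 1 to compound 3 (the limit leaves the size open). Going by these compounds alone, compound 3 is reported only as a limit, > 1 mg/kg, and this limit lies on the other side of the one reported for compound 1. Within the data shown here, this is the first comparison here in which only one place differs, and it shows that this position does not treat the two rings alike, although both are five-membered aromatic rings of 6 heavy atoms with no hydrogen-bond donors and differ in carrying 4 against 2 hetero atoms.

As far as these compounds go, the two limits leave the size of the step open, and it also remains open whether another group at this place, such as a carboxylic acid or a primary amine, would fall on the side of compound 1 or that of compound 3. The data shown hold no measured property that bears on why the two rings differ.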